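Cytotoxicity limits for three compounds and one estimate

A few compounds are considered here, and "the series" means these few. Any claim that something is new, unique, unknown or untested is made for them only; others in the source may bear on it.

Compound 1 `COC(=O)C1=C(C(=O)OC)[C@@H]2N(CCCCCn3cc(-c4ccc(OC)cc4C)nn3)c3ccccc3[C@@]23CCC(=O)N(Cc2ccccc2)C3=N1`: > 100000 nM
Compound 2 `COC(=O)C1=C(C(=O)OC)[C@@H]2N(CCCCCN3c4ccccc4[C@]45CCC(=O)N(Cc6ccccc6)C4=NC(C(=O)OC)=C(C(=O)OC)[C@H]35)c3ccccc3[C@@]23CCC(=O)N(Cc2ccccc2)C3=N1`: > 36000 nM
Compound 3 `COC(=O)C1=C(C(=O)OC)[C@@H]2N(CCCN3c4ccccc4[C@]45CCC(=O)N(Cc6ccccc6)C4=NC(C(=O)OC)=C(C(=O)OC)[C@H]35)c3ccccc3[C@@]23CCC(=O)N(Cc2ccccc2)C3=N1`: > 36000 nM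

In an ADME assay on Huh-7 cells (Homo sapiens) for cytotoxicity (a higher number here means that more compound is tolerated, a lower number that less compound is tolerated), compound 1 gives > 100000 nM, which is a limit of the assay and not a number. Compound 2 likewise gives only a limit, > 36000 nM. Compound 3 also gives a limit, > 36000 nM. Compound 1 thus sits at the limit of > 100000 nM in this assay, at which 1 of the 3 values shown sits, while the other two sit at the limit of > 36000 nM in this assay, at which 2 of the 3 values shown sit; no measured toxicity appears for any of the three. Compound 4 `COC(=O)C1=C(C(=O)OC)[C@@H]2N(CCCCCn3cc(CNC(C)=O)nn3)c3ccccc3[C@@]23CCC(=O)N(Cc2ccccc2)C3=N1` differs from compound 1 by acetamidomethyl in place of 4-methoxy-2-methylphenyl on an aromatic carbon. Within the data shown here, no step between measured compounds exists, and with every value a limit no direction can be read. In this assay compound 4 is expected to stay at the limit, with a step estimated as a number no higher from compound 1 to compound 4 (the limit leaves the size open). For compound 4 the estimate is 100000 nM, with a range from 30000 nM to 300000 nM.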

Compound 4, half-maximal cytotoxic concentration: 150000 nM
Estimate against measurement, compound 4: 1.5-fold (0.18 log units) below, within the range that was stated.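

In this assay, among these compounds, compound 1 gives > 100000 nM, which is a limit, so no step from compound 1 to compound 4 can be read. The compounds shown leave open what acetamidomethyl in place of 4-methoxy-2-methylphenyl changes in this read-out.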